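This account rests on a few compounds, and the source may have more. Where it says the series, first, only, none or still open, it means among the compounds named here.

Values in a functional assay on MCF7 cells (Homo sapiens) for cytotoxicity, read by ELISA, with a stated time of 4 days; a lower number here means a stronger inhibitor, a higher number a weaker inhibitor:

- compound 1 `Cc1ccsc1-c1cc(-c2ccco2)cc(-c2ccccc2Cl)n1`: 14200 nM
- compound 2 `Cc1ccsc1-c1cc(-c2ccoc2)cc(-c2ccco2)n1`: 18300 nM
- compound 3 `Cc1ccc(-c2cc(-c3ccoc3)cc(-c3ccc(Cl)s3)n2)cc1`: 5340 nM

Compound 3 has the lowest number of the three, at 5340 nM. Compound 1 is the nearest to it and compound 2 the furthest, and both stand higher by more than the usual scatter.

The next compound to be tested is compound 4 `Clc1ccc(-c2cc(-c3ccoc3)cc(-c3cccnc3)n2)s1`. It keeps the 5-chlorothiophen-2-yl and furan-3-yl groups of compound 3, with pyridin-3-yl in place of 4-methylphenyl on an aromatic carbon.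

Within the data shown here, no pair of measured compounds differs in one place only, so the size of this change in this assay has no direct precedent. Among the measured compounds shown here, the only guide is loose: compound 3 carries 4-methylphenyl and has the lowest number, while compound 1 at 14200 nM and compound 2 at 18300 nM lack that group but also differ elsewhere. A small move towards a weaker number is therefore expected, possibly no larger than the scatter. The expected change is a 1.6-fold higher number from compound 3 to compound 4 (0.20 log units; within the scatter). For compound 4 the estimated value is 8500 nM, with an expected range of 3000 nM to 24000 nM.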

Compound 4, half-maximal inhibitory concentration: 3480 nM
Compound 4: middle estimate off by 2.4-fold (0.39 log units), on the high side, within the range that was stated.
By their numbers in this assay, from the lowest: compounds 4 and 3 (each within the scatter of the next); then compounds 1 and 2 (each within the scatter of the next).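

In this assay, the series now has its first comparison in one place only, pyridin-3-yl in place of 4-methylphenyl on an aromatic carbon, and it reads a 1.5-fold lower number from compound 3 to compound 4 (0.19 log units; within the scatter) for this exchange. At this position, meta to a 5-chlorothiophen-2-yl group and meta to a furan-3-yl group, a ring of carbon only and a ring with one nitrogen and a hydrogen-bond acceptor cannot be told apart in this read-out, so the 4-methylphenyl group is not needed to keep a number in this range. Among these compounds, nothing measured so far gives a reason for this result.

Still open, from the compounds shown here alone, is whether any group at this position moves the number beyond the scatter, for example pyridin-4-yl, a ring carrying a carboxylic acid, or an aminomethyl chain. Going by these compounds, this rests on a single step with the 5-chlorothiophen-2-yl and furan-3-yl groups held in place, so it remains unknown whether the same exchange reads alike with other groups at those two places.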